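This account rests on a few compounds, and the source may have more. Where it says the series, first, only, none or still open, it means among the compounds named here.

Of the compounds shown here, two have been measured. Compound 2 `COc1cc2cc(Oc3ccc(NC(=O)Nc4ccc(Cl)c(C(F)(F)F)c4)cc3)c(C)nc2cc1OC` gives 1310 nM in a functional assay on COLO 205 cells (Homo sapiens) for inhibition, read by sulforhodamine B assay, with a stated time of 48 h (a higher number here means a weaker inhibitor of growth, a lower number a stronger inhibitor of growth), and compound 1 `COc1cc2cc(Oc3ccc(NC(=O)Nc4cccc(C(F)(F)F)c4)cc3)c(C)nc2cc1OC` gives 2400 nM in this assay. Among the measured compounds shown here, the single step between them, a 1.8-fold lower number from compound 1 to compound 2 (0.26 log units; within the scatter), comes from chloro in place of hydrogen on an aromatic carbon, so compound 2 and compound 1 cannot be told apart on the numbers in hand.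

Compound 3 `COc1cc2cc(Oc3ccc(NC(=O)Nc4ccc(Cl)c(Cl)c4)cc3)c(C)nc2cc1OC` differs from compound 2 by chloro in place of trifluoromethyl on an aromatic carbon. For the measured compounds named here, no measured step covers this exchange; the only step available, chloro in place of hydrogen, stayed within the scatter, which gives no reason to expect a step beyond the scatter here either. The estimate for compound 3 in this assay is therefore 1500 nM, with a range of 600 nM to 4000 nM, corresponding to an expected step of a 1.1-fold higher number from compound 2 to compound 3 (0.06 log units; within the scatter).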

Compound 3, concentration for total growth inhibition: 6500 nM
Compound 3: the middle estimate sits 4.3-fold (0.64 log units) below what was measured; the measured number lies above the stated range.
By their numbers in this assay, from the lowest: compounds 2 and 1 (each within the scatter of the next); then compound 3.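

In this assay, among the compounds shown here, this position, ortho to a chloro group, is the first place where a change leaves the scatter: chloro in place of trifluoromethyl gives a 5.0-fold higher number from compound 2 to compound 3 (0.70 log units; beyond the scatter) and so weakens growth inhibition, which the earlier step of chloro in place of hydrogen did not do. The step from the other side, 3,4-dichlorophenyl in place of 3-(trifluoromethyl)phenyl, gives a 2.7-fold higher number from compound 1 to compound 3 (0.43 log units; beyond the scatter) and points the same way, so in both pairs that reach compound 3 the number rises. Nothing available accounts for the size of this loss.

Going by these compounds, it remains open how a fluoro, a methyl, a methoxy or a nitrile would read in the place of trifluoromethyl. On these data alone, it is equally open whether the same exchange would carry a similar step with a morpholine or a carboxylic acid on the shared core.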